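Replacing a Benzyl Sulfonamide With a Dimethyl Sulfonamide

This account rests on a few compounds, and the source may have more. Where it says the series, first, only, none or still open, it means among the compounds named here.

Of the compounds shown here, three sharing one core have been measured in a functional assay on the whole organism (aorta) with Rattus norvegicus as the target; on this read-out higher numbers stand for larger maximal responses and lower numbers for smaller maximal responses. Compound 1 `CC1(C)C=C(n2ccccc2=O)c2cc(S(=O)(=O)N=[N+]=[N-])ccc2O1` carries an azido group on its sulfonyl sulfur, and in this assay compound 1 gives 88.3%. Compound 2 `CNS(=O)(=O)c1ccc2c(c1)C(n1ccccc1=O)=CC(C)(C)O2` carries a methylamino group there, and compound 2 gives 85.8%. Compound 3 `CC1(C)C=C(n2ccccc2=O)c2cc(S(=O)(=O)NCc3ccccc3)ccc2O1` carries a benzylamino group, and compound 3 gives 71.1%, the lowest of the three numbers; its nearest neighbour is compound 2, beyond the scatter, and its furthest is compound 1.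

The step now followed leads to compound 4 `CN(C)S(=O)(=O)c1ccc2c(c1)C(n1ccccc1=O)=CC(C)(C)O2`, which differs from compound 3 as follows: dimethylamino in place of benzylamino on a sulfonyl sulfur. Going by the values given here, two measured steps bear on this. The change a number 14.7 percentage points lower from compound 2 to compound 3 (beyond the scatter), and the change a number 17.2 percentage points lower from compound 1 to compound 3 (beyond the scatter); both show that a small group on the sulfonyl sulfur sits higher than the benzyl group. Compound 4 returns to a small group, so a rise of similar size is expected, estimated as a number 12.9 percentage points higher from compound 3 to compound 4 (beyond the scatter). For compound 4, the expected response in this assay is therefore 84%, with a likely range from 72% to 95%.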

Compound 4, largest response reached (Emax), in percent of the reference or control that the assay uses: 78.3%
Compound 4: middle estimate off by 5.7 percentage points, on the high side; low and high end bracket the measured number.
By their numbers in this assay, from the lowest: compounds 3, 4, 2 and 1 (each within the scatter of the next, the first and the last beyond it).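

In this assay, putting dimethylamino in place of benzylamino on the sulfonyl sulfur gives a number 7.2 percentage points higher from compound 3 to compound 4 (within the scatter), so this small group, unlike methylamino and azido, does not stand clear of the benzylamino compound, and compound 4 goes against any rule that small groups here always separate from benzylamino. Adding a methyl in place of the last hydrogen on the sulfonamide nitrogen gives a number 7.5 percentage points lower from compound 2 to compound 4 (within the scatter), and the comparison with the azido compound gives a number 10 percentage points lower from compound 1 to compound 4 (within the scatter), so neither losing that hydrogen nor exchanging azido for dimethylamino moves the response beyond the usual scatter of this assay. No measurement shown here explains why these numbers fall as they do.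

Still open, going by these compounds, is whether a larger pair of chains, as in diethylamino, or a ring on the sulfonyl sulfur, as in morpholine or piperidine, would separate from these compounds. On these data alone, it is equally open whether the gap between benzylamino and the two groups methylamino and azido depends on the phenyl ring itself, which a cyclohexylmethylamino group or a longer phenethylamino chain would help to test.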